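One stereocentre redrawn: what compound 3 may show

The source may hold more compounds than are shown below. What is called first, only, known or untested is meant among the compounds shown, and "the series" means these compounds.

Two compounds measured so far in a functional assay on HCT-116 cells (Homo sapiens) for cytotoxicity, read by MTT assay, with a stated time of 72 h (a lower number here means a stronger inhibitor, a higher number a weaker inhibitor), are
- compound 1 `O=C1c2c[n+]([O-])c3ccccc3c2C(=O)c2c1c1ccccc1n2Cc1cn([C@H]2O[C@H](CO)[C@@H](O)[C@H]2O)nn1` with 710 nM as its value
- compound 2 `CC1(C)OC[C@H](Cn2cc(Cn3c4c(c5ccccc53)C(=O)c3c[n+]([O-])c5ccccc5c3C4=O)nn2)O1` with 130 nM as its value

Compound 2 holds the lower of these two numbers, and the gap to compound 1 lies beyond the scatter. The next compound to be tested is compound 3 `CC1(C)OC[C@@H](Cn2cc(Cn3c4c(c5ccccc53)C(=O)c3c[n+]([O-])c5ccccc5c3C4=O)nn2)O1` and it departs from compound 2 in one way only: the two compounds have the same atoms and bonds and differ only in configuration as drawn: 1 of 1 stereo elements differ; a stereocentre at a saturated ring carbon is drawn S in compound 2 and R in compound 3 in all. A stereocentre at a saturated ring carbon is drawn S in compound 2 and R in compound 3, while the atoms and bonds stay the same.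

Within the data shown here, only one measured step is available, a 5.5-fold lower number from compound 1 to compound 2 (0.74 log units; beyond the scatter) for (2,2-dimethyl-1,3-dioxolan-4-yl)methyl in place of 3,4-dihydroxy-5-(hydroxymethyl)oxolan-2-yl on an aromatic nitrogen. That step exchanged a whole group, so it bears only loosely on this change. Among the measured compounds shown here, no measured pair differs in configuration alone, so the direction stays open and no step beyond the scatter is expected in this assay here. The expected step is a 1.2-fold higher number from compound 2 to compound 3 (0.06 log units; within the scatter) on this reading. For compound 3 the estimate is 150 nM within an expected range from 65 nM to 350 nM in this test.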

Compound 3, half-maximal inhibitory concentration: 340 nM
Estimate against measurement, compound 3: 2.3-fold (0.36 log units) below; the range from low to high includes it.
By their numbers in this assay, from the lowest: compound 2; then compound 3; then compound 1.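

Redrawing one stereocentre at a saturated ring carbon from S to R gives, in this assay, a 2.6-fold higher number from compound 2 to compound 3 (0.42 log units; beyond the scatter), so this position responds to configuration as well as to the choice of group. The gap can be assigned to that stereocentre alone, because nothing else separates the pair: the fact that compounds 2 and 3 differ only in the configuration as drawn. The earlier exchange of the 3,4-dihydroxy-5-(hydroxymethyl)oxolan-2-yl group for the (2,2-dimethyl-1,3-dioxolan-4-yl)methyl group now stands in both configurations, as a 5.5-fold lower number from compound 1 to compound 2 (0.74 log units; beyond the scatter) and as a 2.1-fold lower number from compound 1 to compound 3 (0.32 log units; beyond the scatter), so the number falls in the same direction with either form, by an amount that depends on the configuration.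

The compounds shown leave open whether the S form would keep its lower number if the dioxolane ring gave way to an open 2,3-dihydroxypropyl chain or to a chain ending in an amine. They also leave open how far the stereocentres of the oxolane ring in compound 1 bear on its number, and whether the gap between compound 2 and compound 3 appears outside this assay.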